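This account rests on a few compounds, and the source may have more. Where it says the series, first, only, none or still open, it means among the compounds named here.

Measured in an in vitro ADME assay on microsomes from liver (Homo sapiens) for metabolic stability; a higher number here means that the compound lasts longer, a lower number that the compound disappears faster:
- compound 1 `CC(C)CC1n2cncc2CN(Cc2ccc(OC(F)(F)F)cc2)S1(=O)=O`: 0.117 h
- compound 2 `C[C@@H](c1ccc(Cl)cc1)N1Cc2cncn2C(C[C@@H](O)c2ccccc2)S1(=O)=O`: 0.4 h

Compound 2 stands highest of these two numbers at 0.4 h, and its gap to compound 1 lies beyond the scatter.

The next compound is compound 3 `CC(C)CC1n2cncc2CN([C@@H](C)c2ccc(Cl)cc2)S1(=O)=O`, reached from compound 2 by one change: isopropyl in place of hydroxy(phenyl)methyl on a saturated chain carbon bound to a saturated ring carbon. Isopropyl stands in place of hydroxy(phenyl)methyl on a saturated chain carbon bound to a saturated ring carbon. Cut one bond further out, the same difference reads 2-hydroxy-2-phenylethyl to isobutyl.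

Within the data shown here, no pair of measured compounds shows this change on its own, so the data give no direct size for it in this assay. Among the measured compounds shown here, the only guide is compound 1, which carries isobutyl and gives 0.117 h. A downward step is therefore expected, though this rests on a single compound and is weakly supported. The expected change is a 2.0-fold lower number from compound 2 to compound 3 (0.30 log units; within the scatter), which would lie near the edge of the scatter. For compound 3 the estimated half-life is 0.2 h, with an expected range from 0.08 h to 0.45 h.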

Compound 3, half-life: 0.1 h
Compound 3: the middle estimate sits 2.0-fold (0.30 log units) above what was measured, and the stated range covers the measured number.
By their numbers in this assay, from the lowest: compounds 3 and 1 (each within the scatter of the next); then compound 2.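

In this assay the saturated chain carbon bound to a saturated ring carbon now has its first direct reading, as the exchange of hydroxy(phenyl)methyl for isopropyl gives a 4.0-fold lower number from compound 2 to compound 3 (0.60 log units; beyond the scatter) and thus a step that stands beyond the scatter. This change removes the aromatic ring, the hydrogen-bond donor, the hydrogen-bond acceptor and the defined stereocentre of the leaving group together, so this single pair cannot assign the step to any one of these features. Nothing measured here accounts for the size or direction of the step.

Still open, on these data alone, is which part of the 2-hydroxy-2-phenylethyl group goes with the longer half-life, a question that a 2-phenylethyl group without the hydroxyl or a 2-hydroxyethyl group without the phenyl ring could separate at this place. Also open, as far as these compounds go, is how a longer alkyl chain or a primary amine on the same chain carbon would read, and whether the step keeps its size when the other substituent on the shared core is changed.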